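The compounds below may be only part of what the source reports. "The series", "measured", "known", "first", "only" and "open" are said of these compounds alone.

Three compounds have been measured in a functional assay (spleen, spleen) for activation, with Mus musculus as the target; a higher number here means that more compound is needed for the effect, a lower number that less compound is needed:

compound 1, `CNc1nc(N)c2nc(O)n(Cc3ccccc3)c2n1`, 1 uM
compound 2, `Cc1nc(N)c2nc(O)n(Cc3ccccc3)c2n1`, 1 uM
compound 3, `CCCCc1nc(N)c2nc(O)n(Cc3ccccc3)c2n1`, 0.03 uM

Compound 1 stands level with compound 2 at the digits shown, and together they have the highest numbers of the three. Its nearest neighbour is compound 2, no change at the digits printed from compound 1 to compound 2 (within the scatter). Its furthest is compound 3, a 33-fold lower number from compound 1 to compound 3 (1.52 log units; beyond the scatter).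

Compound 4, `Nc1nc(SCc2ccccc2)nc2c1nc(O)n2Cc1ccccc1`, differs from compound 1 in one place: benzylsulfanyl in place of methylamino on an aromatic carbon.

Going by the values given here, two measured steps bear on this change. The step from compound 1 to compound 2 shows that exchanging methylamino for a small group leaves the number where it was. The steps of a 33-fold lower number from compound 1 to compound 3 (1.52 log units; beyond the scatter) and a 33-fold lower number from compound 2 to compound 3 (1.52 log units; beyond the scatter) show that a larger group on this aromatic carbon brings a large drop. Benzylsulfanyl is also a larger group entering at the same carbon, so a lower number is expected for compound 4, though less certain in size since the group differs in kind from butyl. The estimate for compound 4 is 0.1 uM, with a range from 0.02 uM to 0.5 uM, which would be a step of a 10-fold lower number from compound 1 to compound 4 (1.00 log units; beyond the scatter).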

Compound 4, minimum effective concentration: 0.1 uM
Estimate against measurement, compound 4: no gap at the digits printed; low and high end bracket the measured number.
By their numbers in this assay, from the lowest: compound 3; then compound 4; then compounds 1 and 2 (each within the scatter of the next).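

In this assay, the drop seen with butyl at this aromatic carbon between two ring nitrogen atoms is not confined to a plain alkyl chain: benzylsulfanyl, which brings a sulfur and a six-membered aromatic ring of carbon only, gives a 10-fold lower number from compound 1 to compound 4 (1.00 log units; beyond the scatter) and a 10-fold lower number from compound 2 to compound 4 (1.00 log units; beyond the scatter). Large groups at this carbon are nevertheless not interchangeable, since the change from butyl gives a 3.3-fold higher number from compound 3 to compound 4 (0.52 log units; beyond the scatter). Going by these compounds alone, of the groups at this carbon so far, butyl therefore remains the one with the lowest number, and benzylsulfanyl falls short of it while still standing clear of methyl and methylamino.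

Nothing in the data given speaks to what lies behind these steps. Going by these compounds, whether the sulfur or the aromatic ring separates compound 4 from compound 3 remains open, as does where butylsulfanyl, a phenethyl group or a longer chain such as hexyl would stand at this carbon.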